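Same Ring Swap Repeated on a Second Core

The compounds below may be only part of what the source reports. "The series", "measured", "known", "first", "only" and "open" are said of these compounds alone.

Measured so far:
Compound 1, `O=C(NCCNS(=O)(=O)c1ccc(-c2ccccc2Oc2ccc(O)c(O)c2)s1)Nc1cc(Cl)cc(Cl)c1`, in a functional assay on HL-60 cells (Homo sapiens) for inhibition, read by CCK-8 assay, with a stated time of 48 h (on this read-out higher numbers stand for weaker inhibition and lower numbers for stronger inhibition), gives 10400 nM.
Compound 2, `O=C(NCCNS(=O)(=O)c1ccc(-c2ccccc2Oc2ccc([N+](=O)[O-])c([N+](=O)[O-])c2)s1)Nc1cc(Cl)cc(Cl)c1`, in this assay gives 2300 nM.
Compound 3, `O=C(NCCNS(=O)(=O)c1ccc(-c2ccccc2Oc2ccc([N+](=O)[O-])c([N+](=O)[O-])c2)s1)Nc1cc(C(F)(F)F)cc(C(F)(F)F)c1`, in this assay gives 1900 nM.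

Compounds 1 and 2 share one core and differ in a single place. Going from compound 2 to compound 1 the change is 3,4-dihydroxyphenyl in place of 3,4-dinitrophenyl on an oxygen on an aromatic ring. The step this made in this assay was a 4.5-fold higher number from compound 2 to compound 1 (0.66 log units; beyond the scatter), so the dihydroxyphenyl compound inhibits more weakly than its dinitrophenyl partner by a modest but real margin.

Compound 3 carries a different core; how it differs from compound 2 is not broken down here. Its value and that of compound 2 lie within the scatter of each other, so nothing can be said about an order between them.

Compound 4, `O=C(NCCNS(=O)(=O)c1ccc(-c2ccccc2Oc2ccc(O)c(O)c2)s1)Nc1cc(C(F)(F)F)cc(C(F)(F)F)c1`, has not been measured. It stands to compound 3 as compound 1 stands to compound 2: the change is 3,4-dihydroxyphenyl in place of 3,4-dinitrophenyl on an oxygen on an aromatic ring, at the same place, word for word, as before. It is therefore the same change, now on the second core.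

The expectation for compound 4 rests on compound 2 and compound 1, whose step was a 4.5-fold higher number from compound 2 to compound 1 (0.66 log units; beyond the scatter); the step from compound 3 to compound 4 in this assay is expected to be about a 4.5-fold higher number from compound 3 to compound 4 (0.65 log units; beyond the scatter). Compound 4 is thus estimated at 8500 nM, most likely between 4000 nM and 20000 nM.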

Compound 4, half-maximal inhibitory concentration: 10500 nM
Compound 4: the middle estimate sits 1.2-fold (0.09 log units) below what was measured; measured number inside the range.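

In this assay the swap of 3,4-dinitrophenyl for 3,4-dihydroxyphenyl weakens inhibition on the second core too, with a 5.5-fold higher number from compound 3 to compound 4 (0.74 log units; beyond the scatter) as the size of the step. Set beside the first case, the two steps agree: the same change on two cores in this assay, a 4.5-fold higher number (0.66 log units; beyond the scatter) from compound 2 to compound 1 and a 5.5-fold higher number (0.74 log units; beyond the scatter) from compound 3 to compound 4, 1.2-fold (0.09 log units) apart, within the scatter of two such steps. Within these four compounds, then, the change carries from the core of compound 1 to the core of compound 3 with about the same size, but two cores are a small sample: this does not show that the step would hold on any other core, and it does not explain why the dinitrophenyl compounds give the lower numbers.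

The compounds shown change both substituents on that ring together, so it remains open whether the hydroxyl groups, the nitro groups or both set the size of the step, and a ring with a single nitro group or a single hydroxyl group would help separate these. Going by these compounds, it is also open how other groups at the same place, such as an amine or a carboxylic acid on the ring, would compare with the two groups seen here in this cell read-out.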